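Changing the Side Chain of Compound 3

The compounds below may be only part of what the source reports. "The series", "measured", "known", "first", "only" and "open" are said of these compounds alone.

Of the compounds shown here, three sharing one core have been tested in a toxicity assay on HEK-293T cells (Homo sapiens) for cytotoxicity, read by MTT assay, with a stated time of 72 h; on this read-out lower numbers stand for stronger inhibition and higher numbers for weaker inhibition. There, compound 1 `O=C1c2c[n+]([O-])c3ccccc3c2C(=O)c2c1c1ccccc1n2CCCCn1ccnc1` gives 280 nM, compound 2 `O=C1c2c[n+]([O-])c3ccccc3c2C(=O)c2c1c1ccccc1n2Cc1cn(C[C@H](O)CO)nn1` gives 8880 nM, and compound 3 `O=C1c2c[n+]([O-])c3ccccc3c2C(=O)c2c1c1ccccc1n2Cc1cn(C[C@@H](O)CO)nn1` gives 2030 nM. Compound 3 therefore holds the second highest of the three numbers, with compound 1 the lowest and compound 2 the highest.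

The next compound, compound 4 `O=C1c2c[n+]([O-])c3ccccc3c2C(=O)c2c1c1ccccc1n2CCCN1CCC(O)CC1`, has not yet been measured. It differs from compound 3 as follows: 2-(4-hydroxypiperidin-1-yl)ethyl in place of 1-(2,3-dihydroxypropyl)-1H-1,2,3-triazol-4-yl on a saturated chain carbon bound to an aromatic nitrogen. In short, 2-(4-hydroxypiperidin-1-yl)ethyl replaces 1-(2,3-dihydroxypropyl)-1H-1,2,3-triazol-4-yl on a saturated chain carbon bound to an aromatic nitrogen.

The best guides are the two steps that introduced the group now leaving: a 32-fold higher number from compound 1 to compound 2 (1.50 log units; beyond the scatter), which is large, and a 7.3-fold higher number from compound 1 to compound 3 (0.86 log units; beyond the scatter), which is modest. Both raised the number. The group's configuration matters too: a 4.4-fold lower number from compound 2 to compound 3 (0.64 log units; beyond the scatter) is a modest step, and it is due to the fact that compounds 2 and 3 differ only in the configuration as drawn. Among the compounds with values here, removing that group from compound 3 may therefore lower the number, although the new group differs from the one in compound 1, so only part of that gap is expected to be recovered.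

The expected change is modest: a 2.9-fold lower number from compound 3 to compound 4 (0.46 log units; beyond the scatter). For compound 4 the estimated value is 700 nM, with an expected range of 170 nM to 3000 nM.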

Compound 4, half-maximal inhibitory concentration: 170 nM
For compound 4 the middle estimate is 4.1-fold (0.61 log units) above the measured one; the measured number falls inside the stated range.
By their numbers in this assay, from the lowest: compounds 4 and 1 (each within the scatter of the next); then compound 3; then compound 2.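

In this assay, the triazole group at this position can be replaced with a clear gain, as the change gives a 12-fold lower number from compound 3 to compound 4 (1.08 log units; beyond the scatter), and from the other configuration it gives a 52-fold lower number from compound 2 to compound 4 (1.72 log units; beyond the scatter). Both steps make the same replacement and end at the same compound, so the difference in their sizes is due to what separates their starting points: the fact that compounds 2 and 3 differ only in the configuration as drawn

A very different side chain also proves compatible with a low number, since the step of a 1.6-fold lower number from compound 1 to compound 4 (0.22 log units; within the scatter) lies within the scatter, and the 4-hydroxypiperidin-1-yl and (1H-imidazol-1-yl)methyl groups cannot be told apart here.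

The compounds shown do not separate the effect of the triazole ring from that of its 2,3-dihydroxypropyl tail or the methyl link that joins it to the core. A plain piperidin-1-yl or a morpholin-4-yl group on the same propyl chain would test whether the hydroxyl of compound 4 contributes to its number, while a triazole with a simple ethyl group in place of the diol would isolate the role of that tail.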